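The compounds below may be only part of what the source reports. "The series", "measured", "known", "first", "only" and "open" are said of these compounds alone.

Working notes on the series. The read-out throughout is an in vitro assay on HEK385-7 cells for displacement of a labelled ligand from prostaglandin D2 receptor 2 (Homo sapiens); on this read-out higher numbers stand for weaker inhibition and lower numbers for stronger inhibition. Compound 1 `O=C(O)Cc1sc(C(c2ccccc2)c2ccc(O)cc2)nc1-c1ccc(F)cc1` gives 3.4 nM in this assay. Compound 2 `N#Cc1cc(-c2nc(C(c3ccc(F)cc3)c3ccc(F)cc3)sc2CC(=O)O)ccc1F` gives 57 nM in this assay. Going by the values given here, compound 2 thus stands at the highest of the two numbers measured so far; its nearest neighbour is compound 1, whose number lies well below it, a gap beyond the usual scatter. Among the compounds with values here, compounds 1 and 2 differ in more than one place, so no single step between them is counted.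

Compound 3 `O=C(O)Cc1sc(C(c2ccc(F)cc2)c2ccc(F)cc2)nc1-c1ccnc(Cl)c1` has not yet been measured in this assay. It differs from compound 2 in one place: 2-chloropyridin-4-yl in place of 3-cyano-4-fluorophenyl on an aromatic carbon. The group that enters is smaller by two heavy atoms than the group that leaves, the triple bond outside the aromatic rings is gone, and one ring nitrogen arrives in the six-membered ring, while the count of donors and acceptors stays the same.

Within the data shown here, no measured pair isolates this change, so the expectation rests on the standing of compound 2 alone. The step of a 1.6-fold lower number from compound 2 to compound 3 (0.21 log units; within the scatter) is expected to be small, most likely toward a lower number, but not clearly beyond the scatter. Compound 3 is accordingly estimated at 35 nM in this assay, with a range from 8 nM to 150 nM.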

Compound 3, half-maximal inhibitory concentration: 3.1 nM
The estimate for compound 3 lay 11-fold (1.05 log units) above the measured number; measured number below the stated range.
By their numbers in this assay, from the lowest: compounds 3 and 1 (each within the scatter of the next); then compound 2.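

In this assay, going by these compounds alone, the aromatic carbon next to the ring nitrogen and next to the ring atom that bears the carboxymethyl group proves highly sensitive to the group it carries: an 18-fold lower number from compound 2 to compound 3 (1.26 log units; beyond the scatter) is the only single-place step and lies well beyond the scatter. The 3-cyano-4-fluorophenyl group is therefore not required here, and the smaller 2-chloropyridin-4-yl group, with its ring nitrogen and chlorine and without the triple bond, serves far better on this core, although the hydrogen-bond donor and acceptor counts of the two groups are the same. No measurement in hand accounts for the size of this step.

The step changes the ring atoms, the halogen and the nitrile together, so the share of each remains unresolved; pyridin-4-yl without the chlorine, 2-aminopyridin-4-yl and 3-cyanophenyl would each bear on that question. Also open, from the compounds shown here alone, is whether 2-chloropyridin-4-yl gives a step of this size when the large group on the ring differs from that of compound 3, as it does in compound 1.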